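The source may hold more compounds than are shown below. What is called first, only, known or untested is meant among the compounds shown, and "the series" means these compounds.

Compound 1, `CC1(C)CCN(c2ccc(C(=O)NS(=O)(=O)c3ccc(NC(C)(C)CSc4ccccc4)c([N+](=O)[O-])c3)cc2)CC1`, in an assay on isolated protein for displacement of a labelled ligand from Apoptosis regulator Bcl-2 (Homo sapiens), read by fluorescence polarization (a lower number here means a stronger inhibitor, a higher number a weaker inhibitor), gives 67 nM.
Compound 2, `COc1ccccc1CC1(OC)CCN(c2ccc(C(=O)NS(=O)(=O)c3ccc(N[C@H](CCN(C)C)CSc4ccccc4)c([N+](=O)[O-])c3)cc2)CC1`, in this assay gives 1.6 nM.
Compound 3, `CN(C)CC[C@H](CSc1ccccc1)Nc1ccc(S(=O)(=O)NC(=O)c2ccc(N3CCC(=Cc4ccc(F)cc4)CC3)cc2)cc1[N+](=O)[O-]`, in this assay gives 3.4 nM.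

Of these three numbers compound 3 holds the second highest. Its nearest neighbour is compound 2, whose number is lower by a margin beyond the scatter, and the furthest is compound 1, whose number is higher by a margin well beyond the scatter. Compounds 2 and 3 thus sit close together, while compound 1 stands clearly apart from both.

Compound 4, `CN(C)CC[C@H](CSc1ccccc1)Nc1ccc(S(=O)(=O)NC(=O)c2ccc(N3CCC(=Cc4ccccc4C(F)(F)F)CC3)cc2)cc1[N+](=O)[O-]`, is not yet measured. It differs from compound 3 in one place: 2-(trifluoromethyl)phenyl in place of 4-fluorophenyl on a double-bonded chain carbon bound to a double-bonded ring carbon. Among the measured compounds shown here, no measured pair shows a change of this kind, so nothing in the data tells how large a step it brings. With the rest of the structure of compound 3 kept, the step from compound 3 to compound 4 is expected to stay small, most likely within the scatter, with the direction uncertain. Compound 4 is therefore estimated to give 4.5 nM in this assay, with a range from 1.5 nM to 14 nM, which means a step of a 1.3-fold higher number from compound 3 to compound 4 (0.12 log units; within the scatter).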

Compound 4, inhibition constant: 2 nM
Estimate against measurement, compound 4: 2.3-fold (0.35 log units) above; measured number inside the range.
By their numbers in this assay, from the lowest: compounds 2, 4 and 3 (each within the scatter of the next, the first and the last beyond it); then compound 1.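

In this assay, among the compounds shown here, the exchange of 4-fluorophenyl for 2-(trifluoromethyl)phenyl on a double-bonded chain carbon bound to a double-bonded ring carbon gives a 1.7-fold lower number from compound 3 to compound 4 (0.23 log units; within the scatter) and is the first step that can be read. It shows that this place accepts the larger group, with 10 heavy atoms in place of 7, and that the number stays within the scatter while the rest of compound 3 is kept. Nothing available gives a reason for this result.

The step changes the fluorine-bearing group and its place on the phenyl ring at once, so 2-fluorophenyl and 4-(trifluoromethyl)phenyl would be needed to separate the two. Going by these compounds, how an unsubstituted phenyl, a pyridine ring or a phenyl carrying an amine or a carboxylic acid fares here remains open.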